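The compounds below may be only part of what the source reports. "The series", "measured", "known", "first", "only" and "open" are said of these compounds alone.

Measured in a physicochemical assay for solubility, read by HPLC, in phosphate buffer, measured as kinetic solubility, with a stated time of 1 h, at pH 7.4, tested at 250 uM; on this read-out higher numbers stand for higher solubility and lower numbers for lower solubility:
- Compound 1 `O=C(NCCCCc1ccccc1)n1cc(-c2ccccc2)oc1=O`: < 1000 nM, a limit
- Compound 2 `CCCCCNC(=O)n1cc(-c2ccccc2)oc1=O`: < 1000 nM, a limit
- Compound 3 `CCOCCNC(=O)n1cc(-c2ccccc2)oc1=O`: 20000 nM

For the measured compounds named here, compound 3 gives the only actual number in the set, 20000 nM. The other two results stand at the limit of < 1000 nM in this assay, at which 2 of the 3 values shown sit.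

Compound 4 `CC(C)CNC(=O)n1cc(-c2ccccc2)oc1=O` departs from compound 3 in one place: isopropyl in place of ethoxymethyl on a saturated chain carbon bound to an amide-type nitrogen. This puts isopropyl in place of ethoxymethyl on a saturated chain carbon bound to an amide-type nitrogen, so that 2-ethoxyethyl gives way to isobutyl.

Going by the values given here, two measured steps bear on this change, and both are large. The first is an at least 20-fold higher number from compound 2 to compound 3 (1.30 log units; beyond the scatter), and the second is an at least 20-fold higher number from compound 1 to compound 3 (1.30 log units; beyond the scatter). Each leads to the 2-ethoxyethyl chain of compound 3 from a chain without its oxygen, whereas the change to compound 4 runs the opposite way. A large step to a lower number is therefore expected, and the result may well be only a limit.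

The estimated change is a 13-fold lower number from compound 3 to compound 4 (1.12 log units; beyond the scatter). For compound 4 the expected value is 1500 nM, within an estimated range of 300 nM to 7000 nM.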

Compound 4, solubility: < 1000 nM
Compound 4 gave a limit, no number; the forecaster's own chance of this, stated with the estimate: 55%; at least 1.5-fold (0.17 log units) between middle value and limit.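

In this assay compound 4, with its isobutyl chain, gives < 1000 nM, a limit and not a number. The change from 2-ethoxyethyl to isobutyl is an at least 20-fold lower number from compound 3 to compound 4 (1.30 log units; beyond the scatter), so a branched chain without the oxygen now stands with the unbranched chains of compound 1 and compound 2, and among these four compounds only the 2-ethoxyethyl chain of compound 3 gives a number. The step from compound 2 to compound 4 joins two limits and cannot be read, and the set now gathers at one value: the limit of < 1000 nM in this assay, at which 3 of the 4 values shown sit.

On these data alone, how far the three limited compounds lie from that limit stays open. Also open, as far as these compounds go, is whether the oxygen is enough by itself, as a shorter 2-methoxyethyl chain, a hydroxyl group or an amine at this place on the chain would show.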